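The source may hold more compounds than are shown below. What is called first, only, known or untested is meant among the compounds shown, and "the series" means these compounds.

Working notes on the series: in a functional assay on U-87MG ATCC cells for cytotoxicity against U-87 MG (Homo sapiens), read by colorimetric assay and MTT assay (on this read-out lower numbers stand for stronger inhibition and higher numbers for weaker inhibition), compound 2 `CCOC(=O)Cn1c(=O)c(-c2ccc(OC)cc2)cc2c(OC)cc(OC)cc21` gives 10000 nM, level with compound 1 `COc1ccc(-c2cc3cccc(OC)c3nc2O)cc1` at 10000 nM and compound 3 `COc1ccc(-c2cc3c(OC)cc(OC)cc3n(CCCC#N)c2=O)cc1` at 10000 nM. The next compound, compound 4 `COc1ccc(-c2cc3c(OC)cc(OC)cc3n(CCC(=O)OCc3ccccc3)c2=O)cc1`, changes one group of compound 2: (benzyloxycarbonyl)methyl in place of ethoxycarbonyl on a saturated chain carbon bound to an aromatic nitrogen. In words, (benzyloxycarbonyl)methyl stands in place of ethoxycarbonyl on a saturated chain carbon bound to an aromatic nitrogen. Going by the values given here, one measured step bears on this place: no change at the digits printed from compound 2 to compound 3 (within the scatter), with 2-cyanoethyl in place of ethoxycarbonyl. Among the compounds with values here, no measured compound carries the six-membered aromatic ring that enters here, so that part remains untested. In this assay the expected step is no change at the digits printed from compound 2 to compound 4 (within the scatter), none beyond the scatter. For compound 4 the estimated value is 10000 nM, with an expected range of 5000 nM to 20000 nM.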

Compound 4, half-maximal inhibitory concentration: 10000 nM
For compound 4 middle estimate and measured number coincide at the digits printed, within the range that was stated.
By their numbers in this assay, from the lowest: compounds 1, 2, 3 and 4 (each within the scatter of the next).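

In this assay the (benzyloxycarbonyl)methyl group, the first at this place to carry a six-membered aromatic ring of carbon only, gives no change at the digits printed from compound 2 to compound 4 (within the scatter) and benzyloxycarbonyl in place of cyanomethyl gives no change at the digits printed from compound 3 to compound 4 (within the scatter). The larger group of 11 heavy atoms therefore leaves the read-out level with both the ethoxycarbonyl and the 2-cyanoethyl compounds. Nothing on hand gives a reason for this level result. From the compounds shown here alone, whether an amine or a carboxylic acid on this chain would move the value away from this level stays open.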